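Bifuran amidine series: chloro for methoxy at the aryl terminus

A few compounds are considered here, and "the series" means these few. Any claim that something is new, unique, unknown or untested is made for them only; others in the source may bear on it.

Measured so far:
compound 1 `N=C(N)c1ccc(-c2ccc(-c3cc(Cl)cc(Cl)c3)s2)s1`: 1850 nM
compound 2 `COc1ccc(-c2ccc(-c3ccc(C(=N)N)o3)o2)cc1`: 3970 nM

In a functional assay on Malme-3M cells (Homo sapiens) for inhibition, read by sulforhodamine B assay, with a stated time of 48 h (a lower number here means a stronger inhibitor of growth, a higher number a weaker inhibitor of growth), compound 2 gives the higher of the two numbers; compound 1 gives a lower number, and the gap lies beyond the scatter. Among the compounds with values here, no single-change step between measured compounds is available here.

Compound 3 `N=C(N)c1ccc(-c2ccc(-c3ccc(Cl)cc3)o2)o1` differs from compound 2 in one place: chloro in place of methoxy on an aromatic carbon, para to a large group. Within the data shown here, no measured pair isolates this change, so the expected step of a 1.4-fold lower number from compound 2 to compound 3 (0.15 log units; within the scatter) is small, toward a somewhat lower number, and may fall within the scatter. Compound 3 is estimated at 2800 nM, range 1200 nM to 7000 nM.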

Compound 3, concentration for 50% growth inhibition: 1910 nM
Compound 3: the middle estimate sits 1.5-fold (0.17 log units) above what was measured, and the stated range covers the measured number.
By their numbers in this assay, from the lowest: compounds 1 and 3 (each within the scatter of the next); then compound 2.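

Within the data shown here, with this assay as the read-out, this position gives the first single-place step: chloro in place of methoxy on the aromatic carbon, para to a large group, gives a 2.1-fold lower number from compound 2 to compound 3 (0.32 log units; beyond the scatter). The number at this position therefore responds to the change of group, though the step is modest and rests on this one pair. No measurement shown accounts for the step.

From the compounds shown here alone, whether an amine or an ethoxy group at this position would shift the number remains open. So does whether the same change would give a similar step on the core of compound 1.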